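Adding methoxy to a compound at the assay limit

The source may hold more compounds than are shown below. What is called first, only, known or untested is meant among the compounds shown, and "the series" means these compounds.

Measured so far in a functional assay on HL-60 cells (Homo sapiens) for antiproliferative activity (on this read-out lower numbers stand for stronger inhibition and higher numbers for weaker inhibition), both values being limits of the assay:
Compound 1 `CCOC(=O)c1ccc(Oc2ccc(N(C)C)cc2)cc1O` gives > 30000 nM
Compound 2 `CCOC(=O)c1ccc(Oc2ccc(OC)cc2)cc1O` gives > 30000 nM

Compound 2 gives > 30000 nM in this assay, which is a limit and not a number. It has no company among measured numbers here: the limit of > 30000 nM in this assay, at which 2 of the 2 values shown sit. The next compound, compound 3 `CCOC(=O)c1ccc(Oc2ccc(OC)c(OC)c2)cc1O`, carries methoxy in place of hydrogen on an aromatic carbon. This is methoxy in place of hydrogen on an aromatic carbon, ortho to a methoxy group and meta to a large group. For the measured compounds named here, the only measured step that bears on it is a step that the two limits leave unreadable from compound 1 to compound 2, which offers no size to carry over. No step beyond the scatter can therefore be expected in this assay, in either direction. The estimated step is a number no higher from compound 2 to compound 3 (the limit leaves the size open). For compound 3 the expected value is 30000 nM, with an estimated range of 12000 nM to 60000 nM.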

Compound 3, half-maximal inhibitory concentration: 1500 nM
Compound 3: the middle estimate sits 20-fold (1.30 log units) above what was measured; the whole stated range lies above it.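

In this assay, methoxy in place of hydrogen on an aromatic carbon, ortho to a methoxy group and meta to a large group, brings an at least 20-fold lower number from compound 2 to compound 3 (1.30 log units; beyond the scatter). For the compounds shown here, this is the first step whose size can be read at all, and it shows that the compounds respond to a change at this position, whereas the earlier change from dimethylamino to methoxy could not be read. The size stays open on one side, since compound 3 alone has a measured number and the others sit at a limit of the assay: the limit of > 30000 nM in this assay, at which 2 of the 3 values shown sit.

As far as these compounds go, whether a hydroxyl, a fluorine or an ethoxy group at this position would do the same as methoxy stays open. Also open, from the compounds shown here alone, is whether the added methoxy would have this effect without the methoxy group ortho to it.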